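Cytotoxicity limits in the series, from compound 3 to compound 4

A few compounds are considered here, and "the series" means these few. Any claim that something is new, unique, unknown or untested is made for them only; others in the source may bear on it.

Of the compounds shown here, three have been read in an ADME assay on HEK-293T cells (Homo sapiens) for cytotoxicity, read by CCK-8 assay, with a stated time of 24 h; on this read-out lower numbers stand for higher toxicity in this test and higher numbers for lower toxicity in this test. Compound 1 `O=C(CSc1c[nH]c2c(Br)cccc12)N(Cc1ccccc1)Cc1ccccc1` gives > 100000 nM, which is a limit of the assay. Compound 2 `O=C(CSc1c[nH]c2ccccc12)NCc1ccccc1` gives > 100000 nM, again a limit. Compound 3 `COc1ccccc1CNC(=O)CSc1c[nH]c2cc(Br)ccc12` gives > 100000 nM, also a limit, so it has no number of its own. Among the compounds with values here, the whole series so far is summed up by the limit of > 100000 nM in this assay, at which 3 of the 3 values shown sit.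

The change to compound 4 `O=C(CSc1c[nH]c2cc(Br)ccc12)NCc1ccc(Cl)c(Cl)c1` is 3,4-dichlorophenyl in place of 2-methoxyphenyl on a saturated chain carbon bound to an amide-type nitrogen. Here 3,4-dichlorophenyl comes in place of 2-methoxyphenyl on a saturated chain carbon bound to an amide-type nitrogen.

Within the data shown here, no measured step exists, so limits alone give no size of change in this assay. The expectation is for no change beyond the scatter, and any real number that appears would be expected on the side of higher toxicity in this test. The only anchor for this expectation is compound 3 at > 100000 nM, a limit. The estimated step is a number no higher from compound 3 to compound 4 (the limit leaves the size open). Compound 4 is estimated at 100000 nM, with an expected range from 40000 nM to 200000 nM.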

Compound 4, half-maximal cytotoxic concentration: 67600 nM
Compound 4: the middle estimate sits 1.5-fold (0.17 log units) above what was measured; the range from low to high includes it.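

In this assay, within the data shown here, compound 4 is the first compound of the series to give a number rather than a limit, 67600 nM, so a group on this saturated chain carbon bound to an amide-type nitrogen can bring the reading inside the range of the test. With 3,4-dichlorophenyl in place of 2-methoxyphenyl, the printed floor is an at least 1.4-fold lower number from compound 3 to compound 4 (0.17 log units; that floor lies within the scatter), so the change is not shown to exceed the scatter. The series still sits mostly at one limit: the limit of > 100000 nM in this assay, at which 3 of the 4 values shown sit.

From the compounds shown here alone, compound 3 gives > 100000 nM, which is a limit, so the full size of the step remains open. Also open, going by these compounds, is how the reading in this test would respond to an amine or a carboxylic acid in place of the 3,4-dichlorophenyl group at the same place.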